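From 3,5-dibromophenyl to naphthalen-1-yl on the shared core

The source may report more compounds than this note shows. Statements on the series, on what has been measured and on what is new or still open speak of the compounds shown alone.

compound 1 `Cc1cc(S(N)(=O)=O)ccc1NC(=O)COc1ccc(Cl)cc1NC(=O)c1cccc(Cl)c1`: 59700 nM
compound 2 `Cc1cc(C)cc(C(=O)Nc2cc(Cl)ccc2OCC(=O)Nc2ccc(S(N)(=O)=O)cc2C)c1`: 36500 nM
compound 3 `Cc1cc(S(N)(=O)=O)ccc1NC(=O)COc1ccc(Cl)cc1NC(=O)c1cc(Br)cc(Br)c1`: 89700 nM

In a functional assay on C8166 cells (Homo sapiens) for cytotoxicity, read by MTT assay (a higher number here means that more compound is tolerated, a lower number that less compound is tolerated), compound 3 stands within the scatter of one neighbour, with a 1.5-fold higher number from compound 1 to compound 3 (0.18 log units; within the scatter). It is clearly separated only from the other, with a 2.5-fold higher number from compound 2 to compound 3 (0.39 log units; beyond the scatter). Compound 4 `Cc1cc(S(N)(=O)=O)ccc1NC(=O)COc1ccc(Cl)cc1NC(=O)c1cccc2ccccc12` has not yet been measured. It keeps the shared core and differs at one place: naphthalen-1-yl in place of 3,5-dibromophenyl on a carbonyl carbon. In short, it carries naphthalen-1-yl in place of 3,5-dibromophenyl on a carbonyl carbon.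

Within the data shown here, no measured compound carries this group, so the only guide is the set of swaps already made at the same place. Besides the two steps above, these include a 1.6-fold lower number from compound 1 to compound 2 (0.21 log units; within the scatter). All three are small, and only one passes the scatter, modestly. A small step downward is therefore expected, or none beyond the scatter, and the data do not firmly settle the direction. The estimated change is a 1.5-fold lower number from compound 3 to compound 4 (0.17 log units; within the scatter). For compound 4 the expected value is 60000 nM, with an estimated range from 27000 nM to 130000 nM.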

Compound 4, half-maximal cytotoxic concentration: > 381000 nM
Compound 4 gave a limit, no number; the forecaster's own chance of this, stated with the estimate: 15%; middle value at least 6.3-fold (0.80 log units) away from the limit.
By their numbers in this assay, from the lowest: compounds 2, 1 and 3 (each within the scatter of the next, the first and the last beyond it). At a limit, above all of these: compound 4.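

In this assay compound 4 gives a limit and not a number: the limit of > 381000 nM in this assay, at which 1 of the 4 values shown sits. The position thus allows a much larger change than the earlier swaps suggested: an at least 4.2-fold higher number from compound 3 to compound 4 (0.62 log units; beyond the scatter), an at least 6.3-fold higher number from compound 1 to compound 4 (0.80 log units; beyond the scatter) and an at least 10-fold higher number from compound 2 to compound 4 (1.01 log units; beyond the scatter), the last of these large. Naphthalen-1-yl, the only group shown with 2 six-membered aromatic rings, sets compound 4 apart from the three compounds that carry a single ring at this carbonyl carbon.

As far as these compounds go, how far compound 4 lies past its limit stays open, as does whether the change in the read-out follows from the second ring or from the loss of the two bromine atoms. The compounds shown also do not tell how a group carrying an amine or a carboxylic acid would behave in this place.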